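The compounds below may be only part of what the source reports. "The series", "measured", "known", "first", "only" and "open" are said of these compounds alone.

Compound 1 `COc1ccc2c(=O)c(Cc3c(OC(C)=O)ccc4c(C)cc(=O)oc34)c(N(C)C)oc2c1` was tested in an ADME assay on MT4 cells (Homo sapiens) for cytotoxicity, read by MTT assay, with a stated time of 96 h (on this read-out higher numbers stand for lower toxicity in this test and lower numbers for higher toxicity in this test), and gave 42000 nM. Compound 2 `COc1ccc2[nH]cc(Cc3c(OC(C)=O)ccc4c(C)cc(=O)oc34)c2c1`, which differs in several places, gave 72000 nM in this assay; the two numbers lie within the usual scatter of each other, so neither stands apart. Compound 3 `COc1ccc2c(=O)c(Cc3c(OC(C)=O)ccc4ccc(=O)oc34)c(N(C)C)oc2c1` has not yet been measured. It differs from compound 1 by hydrogen in place of methyl on an aromatic carbon, a small trimming of the shared core. Within the data shown here, with no comparable step among the measured pair to lean on, the expected step from compound 1 to compound 3 is a 1.1-fold lower number from compound 1 to compound 3 (0.02 log units; within the scatter), none beyond the scatter. Compound 3 is thus estimated at 40000 nM, within 20000 nM to 80000 nM.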

Compound 3, half-maximal cytotoxic concentration: 26000 nM
For compound 3 the middle estimate is 1.5-fold (0.19 log units) above the measured one, within the range that was stated.
By their numbers in this assay, from the lowest: compounds 3, 1 and 2 (each within the scatter of the next, the first and the last beyond it).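

In this assay hydrogen in place of methyl on the aromatic carbon opposite the ring oxygen gives a 1.6-fold lower number from compound 1 to compound 3 (0.21 log units; within the scatter) and stays within the scatter. Among these compounds, this is the only pair here differing in one place, and it shows that this methyl can be removed with no step this test can separate from repeat scatter. Nothing measured here bears on what lies behind so small a step. On these data alone, whether a larger group at this position, such as an ethyl, a phenyl or an amine, would move the number remains open.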